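A few compounds are considered here, and "the series" means these few. Any claim that something is new, unique, unknown or untested is made for them only; others in the source may bear on it.

In an assay on CHO cells for antagonist activity at transient receptor potential cation channel subfamily V member 1 (Homo sapiens), read by FLIPR (on this read-out lower numbers stand for stronger inhibition and higher numbers for weaker inhibition), compound 2 `CC(C(=O)NCc1ccc(C(F)(F)F)nc1-c1ccc(C(C)(C)C)cc1)c1ccc(NS(C)(=O)=O)c(F)c1` gives 0.5 nM, the lowest of the two numbers recorded so far, while compound 1 `CC(C(=O)NCc1ccc(C(F)(F)F)nc1-c1ccc(N(C)C)cc1)c1ccc(NS(C)(=O)=O)c(F)c1` gives 3.2 nM. Within the data shown here, the single step seen is a 6.4-fold lower number from compound 1 to compound 2 (0.81 log units; beyond the scatter). Compound 3 `CC(C(=O)NCc1ccc(C(F)(F)F)nc1-n1ccnc1)c1ccc(NS(C)(=O)=O)c(F)c1` differs from compound 2 by 1H-imidazol-1-yl in place of 4-(tert-butyl)phenyl on an aromatic carbon. Among the measured compounds shown here, no measured step covers this exchange; the step from compound 1 to compound 2 shows only that the group at this position moves the number by a modest amount. A larger step toward a higher number is therefore expected, roughly a 30-fold higher number from compound 2 to compound 3 (1.48 log units; beyond the scatter). Compound 3 is estimated at 15 nM, within 2 nM to 150 nM.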

Compound 3, inhibition constant: 36.1 nM
Compound 3: middle estimate off by 2.4-fold (0.38 log units), on the low side, and the stated range covers the measured number.
By their numbers in this assay, from the lowest: compound 2; then compound 1; then compound 3.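

In this assay, exchanging the whole substituted phenyl for 1H-imidazol-1-yl gives a 72-fold higher number from compound 2 to compound 3 (1.86 log units; beyond the scatter) and an 11-fold higher number from compound 1 to compound 3 (1.05 log units; beyond the scatter), both large, whereas changing only the group carried on that phenyl gave the modest 6.4-fold lower number from compound 1 to compound 2 (0.81 log units; beyond the scatter). The aromatic carbon next to the ring nitrogen is therefore more sensitive to replacing the ring than the first pair could show. Nothing available here explains this loss.

The compounds shown leave open whether the ring's size or its nitrogens matter more. An unsubstituted phenyl, a 1H-pyrrol-1-yl or a 4-(tert-butyl)-substituted imidazole at this position would help separate the two.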